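The compounds below may be only part of what the source reports. "The series", "measured", "known", "first", "only" and "open" are said of these compounds alone.

Measured compounds:
compound 1, `CCOC(=O)c1nc(C)c2c(c1N)C(=O)N(Cc1ccccc1)C2=O`, > 100000 nM
compound 2, `Cc1nc(C(=O)NO)c(N)c2c1C(=O)N(Cc1ccccc1)C2=O`, "not determined" (no result reported)

In an ADME assay on Vero cells (Chlorocebus sabaeus) for cytotoxicity, read by MTT assay (a higher number here means a weaker inhibitor, a lower number a stronger inhibitor), compound 1 gives > 100000 nM, which is a limit of the assay rather than a number. For compound 2 the outcome in this assay is "not determined" (no result reported), so compound 2 stands on no single number here; of the two results shown, one sits at the limit of > 100000 nM in this assay, at which 1 of the 2 values shown sits, and the other is absent. Compound 3, `Cc1nnc(-c2nc(C)c3c(c2N)C(=O)N(Cc2ccccc2)C3=O)o1`, has not yet been tested. It differs from compound 2 by 5-methyl-1,3,4-oxadiazol-2-yl in place of hydroxycarbamoyl on an aromatic carbon. Among the measured compounds shown here, with no measured step of this kind, the size and direction of the change cannot be read from the data, and no shift beyond the usual scatter is expected in this assay. Compound 3 is therefore estimated at 100000 nM in this assay, with a range from 30000 nM to 300000 nM, and most likely again only a limit.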

Compound 3, half-maximal inhibitory concentration: > 100000 nM
Compound 3 gave a limit, no number; the forecaster's own chance of this, stated with the estimate: 70%; the middle value sits exactly at the limit.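

Compound 1 and compound 3 each give only a limit of the assay, not a number, so no step between them can be read in this assay: the limit of > 100000 nM in this assay, at which 2 of the 3 values shown sit.

The compounds shown leave open where their true values lie, and whether swapping the group on the aromatic carbon changes anything in this assay.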